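The compounds below may be only part of what the source reports. "The series", "measured", "known", "first", "only" and "open" are said of these compounds alone.

Measured compounds in a functional assay on PC-3 cells (Homo sapiens) for inhibition, read by sulforhodamine B assay, with a stated time of 48 h; a lower number here means a stronger inhibitor of growth, a higher number a weaker inhibitor of growth:
compound 1 `COc1cc(-c2nn(-c3cccc(NC(=O)c4cccc(C(F)(F)F)c4)c3)cc2-c2ccncc2)ccc1Cl` — 1230 nM
compound 2 `O=C(Nc1cccc(-n2cc(-c3ccncc3)c(-c3ccc(Cl)c(O)c3)n2)c1)Nc1cc(C(F)(F)F)cc(C(F)(F)F)c1` — 319 nM
compound 3 `O=C(Nc1cccc(-n2cc(-c3ccncc3)c(-c3ccc(Cl)c(O)c3)n2)c1)Nc1ccc(Cl)c(C(F)(F)F)c1` — 5880 nM

Among these three numbers compound 1 sits second highest: compound 2 gives a lower number, a gap beyond the scatter, while compound 3 gives a higher number, also beyond the scatter. For the measured compounds named here, no two of the measured compounds differ in one place only, so no single step between them can be isolated; what the values show is simply a wide spread across the three.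

Compound 4 `COc1cc(-c2nn(-c3cccc(NC(=O)Nc4ccc(Cl)c(Cl)c4)c3)cc2-c2ccncc2)ccc1Cl` is not yet measured. It differs from compound 1 as follows: (3,4-dichlorophenyl)amino in place of 3-(trifluoromethyl)phenyl on a carbonyl carbon. Given the spread seen between compound 2 and compound 3, and that neither shares the core of compound 1 exactly, the step is expected to be modest and upward, toward a weaker inhibitor, though possibly within the scatter: the expected step is a 1.6-fold higher number from compound 1 to compound 4 (0.21 log units; within the scatter). For compound 4 the expected value in this assay is 2000 nM, with a range from 500 nM to 8000 nM.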

Compound 4, concentration for 50% growth inhibition: 554 nM
The estimate for compound 4 lay 3.6-fold (0.56 log units) above the measured number; measured number inside the range.
By their numbers in this assay, from the lowest: compounds 2 and 4 (each within the scatter of the next); then compound 1; then compound 3.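

In this assay the series now has its first comparison that differs in one place: on a carbonyl carbon whose other neighbour is an amide-type nitrogen, (3,4-dichlorophenyl)amino in place of 3-(trifluoromethyl)phenyl gives a 2.2-fold lower number from compound 1 to compound 4 (0.35 log units; beyond the scatter), so this position tolerates the change and growth inhibition gains modestly. The step combines two differences, the entering amino nitrogen with its hydrogen-bond donor and the two chlorines in place of trifluoromethyl, and the pair cannot assign the gain to either one. Nothing available gives a reason for this step.

The compounds shown leave open how much of the step belongs to the amino nitrogen alone, which (3-(trifluoromethyl)phenyl)amino on the same carbonyl carbon would address. Also open, on these data alone, is how this position responds to a group of a different kind, such as a morpholine or a carboxylic acid in place of the dichlorophenyl ring.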